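A few compounds are considered here, and "the series" means these few. Any claim that something is new, unique, unknown or untested is made for them only; others in the source may bear on it.

Measured so far in a functional assay on HT-29 cells (Homo sapiens) for cytotoxicity, read by MTT assay, with a stated time of 24 h, tested at 1.6 ug/mL; a higher number here means a stronger effect of the compound at the concentration tested, a lower number a weaker effect:

- compound 1, `Cc1ccc2oc(SCC(=O)Nc3ccc(-c4nc(-c5ccccc5)c(-c5ccccc5)n4C)cc3)nc2c1`: 15.5%
- compound 2, `CCN1CCN(CC(=O)Nc2ccc(-c3nc(-c4ccccc4)c(-c4ccccc4)n3C)cc2)CC1`: 13.9%

Compound 1 holds the highest of the two numbers, but its nearest neighbour is compound 2, and the step of a number 1.6 percentage points lower from compound 1 to compound 2 (within the scatter) sits within the scatter, so the two are not told apart by this assay.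

Compound 3, `CN(C)/C=C/N1CCN(CC(=O)Nc2ccc(-c3nc(-c4ccccc4)c(-c4ccccc4)n3C)cc2)CC1`, is not yet measured. It differs from compound 1 in one place: 4-(2-(dimethylamino)ethenyl)piperazin-1-yl in place of (5-methyl-1,3-benzoxazol-2-yl)sulfanyl on a saturated chain carbon bound to a carbonyl carbon

For the measured compounds named here, the only measured step that bears on this change is the one from compound 1 to compound 2, where a 4-ethylpiperazin-1-yl entered for the (5-methyl-1,3-benzoxazol-2-yl)sulfanyl on the saturated chain carbon bound to the carbonyl carbon, and a number 1.6 percentage points lower from compound 1 to compound 2 (within the scatter) resulted. Compound 3 again puts a piperazin-1-yl at that carbon, carrying a 2-(dimethylamino)ethenyl instead of an ethyl. With a single comparison of this kind and both measured values lying close together, no step beyond the scatter is expected for compound 3, and the expected step is a number 1.5 percentage points lower from compound 1 to compound 3 (within the scatter).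

Compound 3 is therefore estimated at 14% in this assay, with a range from 4% to 26%.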

Compound 3, a percentage reported as activity, at one concentration (the size of the read-out at that concentration, not a potency): 8%
The estimate for compound 3 lay 6 percentage points above the measured number; the range from low to high includes it.
By their numbers in this assay, from the lowest: compounds 3, 2 and 1 (each within the scatter of the next).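

In this assay, the saturated chain carbon bound to the carbonyl carbon now has a third group, and the exchange of (5-methyl-1,3-benzoxazol-2-yl)sulfanyl for 4-(2-(dimethylamino)ethenyl)piperazin-1-yl gives a number 7.5 percentage points lower from compound 1 to compound 3 (within the scatter), so this second piperazine-bearing replacement also stays inside the scatter, even with two groups of equal heavy-atom count but different ring content. The series also gains its first reading of a change on the amine nitrogen in a ring: 2-(dimethylamino)ethenyl in place of ethyl gives a number 5.9 percentage points lower from compound 2 to compound 3 (within the scatter), so the three compounds are not told apart, at this position or at that nitrogen. No supporting measurement is available to account for these readings.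

Still open, on these data alone, is whether any group on the saturated chain carbon, such as a morpholin-4-yl, a primary amine or a carboxylic acid, would give a step beyond the scatter. A single-concentration read-out also leaves open how these compounds would compare in potency, and whether a longer chain between the carbonyl carbon and the piperazin-1-yl would change the reading.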